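The compounds below may be only part of what the source reports. "The series", "measured", "known", "first", "only" and "open" are said of these compounds alone.

Compound 1 `Nc1ccccc1NC(=O)c1ccc(CSC(=S)N2CCN(c3ccncc3)CC2)cc1` gives 90.7% in a functional assay on A-375 cells (Homo sapiens) for antiproliferative activity, read by CCK-8 assay, with a stated time of 72 h, tested at 8 uM; on this read-out lower numbers stand for a weaker effect and higher numbers for a stronger effect at the one concentration tested. Compound 2 `Nc1ccccc1NC(=O)c1ccc(CSC(=S)N2CCN(c3cnccn3)CC2)cc1` gives 85.8% in this assay; the step of a number 4.9 percentage points lower from compound 1 to compound 2 (within the scatter) lies within the scatter, so the two numbers cannot be ranked against each other. Compound 3 `Nc1ccccc1NC(=O)c1ccc(CSC(=S)N2CCN(Cc3ccccc3)CC2)cc1` is not yet measured and differs from compound 2 by benzyl in place of pyrazin-2-yl on an amine nitrogen in a ring. Among the compounds with values here, the only measured step, a number 4.9 percentage points lower from compound 1 to compound 2 (within the scatter), exchanged pyridin-4-yl for pyrazin-2-yl on the same ring nitrogen and bears only loosely on a benzyl replacement, so no shift beyond the scatter is expected in this assay, though the benzyl case is untested. Compound 3 is expected at 82%, within 65% to 95%. The step of a number 3.8 percentage points lower from compound 2 to compound 3 (within the scatter) is estimated to remain within the scatter.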

Compound 3, a percentage reported as inhibition, at one concentration (the size of the read-out at that concentration, not a potency): 29.3%
For compound 3 the middle estimate is 52.7 percentage points above the measured one; the measured number lies below the stated range.
By their numbers in this assay, from the lowest: compound 3; then compounds 2 and 1 (each within the scatter of the next).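

Benzyl on the amine nitrogen in a ring gives a number 56.5 percentage points lower from compound 2 to compound 3 (beyond the scatter) in this assay, and against pyridin-4-yl it gives a number 61.4 percentage points lower from compound 1 to compound 3 (beyond the scatter). This position is therefore not indifferent to its substituent, although the exchange between pyridin-4-yl and pyrazin-2-yl had stayed within the scatter. Nothing available explains the loss.

Still open, going by these compounds, is whether the loss follows from the ring of carbon only or from the extra carbon that attaches it. Phenyl and pyridin-4-ylmethyl at this nitrogen would separate these two changes.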